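The source may report more compounds than this note shows. Statements on the series, on what has been measured and on what is new or still open speak of the compounds shown alone.

Of the compounds shown here, three sharing one core have been tested in a functional assay on A549 cells (Homo sapiens) for cytotoxicity, read by MTT assay, with a stated time of 4 days; on this read-out lower numbers stand for stronger inhibition and higher numbers for weaker inhibition. Compound 1 `C=C1C(=O)[C@]23C[C@@]1(O)CC[C@H]2c1ccc(OS(=O)(=O)c2ccc(C)cc2)c(C)c1[C@@H]3Cn1cc(-c2ccccn2)nn1` carries a pyridin-2-yl group, and in this assay compound 1 gives 2310 nM. Among the measured compounds shown here, compound 2 `C=C1C(=O)[C@]23C[C@@]1(O)CC[C@H]2c1ccc(O)c(C)c1[C@@H]3Cn1cc(-c2ccc(C)cc2)nn1` carries a 4-methylphenyl group but differs from the other two in a second place as well, so no single step joins it to them; in this assay compound 2 gives 1260 nM. Compound 3 `C=C1C(=O)[C@]23C[C@@]1(O)CC[C@H]2c1ccc(OS(=O)(=O)c2ccc(C)cc2)c(C)c1[C@@H]3Cn1cc(-c2ccc(F)cc2)nn1` carries a 4-fluorophenyl group in place of the pyridin-2-yl of compound 1, and in this assay compound 3 gives 1950 nM. Compound 3 thus stands second highest of the three numbers, with compound 1 nearest and compound 2 furthest, yet all three lie within the scatter of one another, so no order among them can be read.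

Compound 4 `C=C1C(=O)[C@]23C[C@@]1(O)CC[C@H]2c1ccc(OS(=O)(=O)c2ccc(C)cc2)c(C)c1[C@@H]3Cn1cc(-c2ccc(C)cc2)nn1` differs from compound 3 in one place: methyl in place of fluoro on an aromatic carbon. For the measured compounds named here, the one measured step that touches this same aromatic group, a 1.2-fold lower number from compound 1 to compound 3 (0.07 log units; within the scatter), changed little, and compound 2, which already carries the 4-methylphenyl group, gives a number close to that of compound 3. Nothing here points to a change beyond the scatter, so the step expected in this assay is a 1.1-fold lower number from compound 3 to compound 4 (0.03 log units; within the scatter). For compound 4 the estimate in this assay is 1800 nM, expected to fall between 900 nM and 3600 nM.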

Compound 4, half-maximal inhibitory concentration: 1830 nM
For compound 4 the middle estimate is 1.0-fold (0.01 log units) below the measured one; measured number inside the range.
By their numbers in this assay, from the lowest: compounds 2, 4, 3 and 1 (each within the scatter of the next).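

In this assay, methyl in place of fluoro, para to a large group, gives a 1.1-fold lower number from compound 3 to compound 4 (0.03 log units; within the scatter), and 4-methylphenyl in place of pyridin-2-yl gives a 1.3-fold lower number from compound 1 to compound 4 (0.10 log units; within the scatter), so all three groups now tested at this position on the triazole-bound aromatic substituent read alike within the scatter. Among the compounds shown here, the new compound also supplies the first single step at the oxygen on the aromatic ring, where (4-methylphenyl)sulfonyl in place of hydrogen gives a 1.5-fold higher number from compound 2 to compound 4 (0.16 log units; within the scatter), again within the scatter, so with the 4-methylphenyl group in place, the free oxygen-hydrogen and the sulfonyl-bearing form cannot be told apart in this assay. No measurement shown here offers an explanation for these small steps.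

As far as these compounds go, whether a group of another kind at this position, such as an amine, a carboxylic acid or a longer chain, would move the number beyond the scatter remains open. From the compounds shown here alone, it is also open whether the step at the oxygen would stay this small with 4-fluorophenyl or pyridin-2-yl in place of 4-methylphenyl.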